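A few compounds are considered here, and "the series" means these few. Any claim that something is new, unique, unknown or untested is made for them only; others in the source may bear on it.

In an assay on HEK293 cells for positive allosteric modulation of metabotropic glutamate receptor 3 (Rattus norvegicus), read by thallium flux, with a stated time of 2.5 min (a higher number here means a larger maximal response, a lower number a smaller maximal response), compound 1 `CCCC(=O)c1ccc(OCCCCOc2ccc(F)c(C(=O)O)c2)c(C)c1O` gives 56.9%. Among the three compounds measured so far it stands second highest. Compound 3 `Cc1c(OCCCCOc2ccc(C(=O)O)cc2Cl)ccc(C(=O)CC(C)C)c1O` gives 62.9%, a number that lies within the usual scatter of compound 1, so no order between the two can be read. Compound 2 `Cc1c(OCCCCOc2ccc(C(=O)C(C)C)c(O)c2C)cccc1C(=O)O` gives 27.1%, a number beyond the scatter below compound 1.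

Compound 4 `CCC(=O)c1ccc(OCCCCOc2ccc(F)c(C(=O)O)c2)c(C)c1O` has not yet been measured in this assay. It differs from compound 1 in a single place: hydrogen in place of methyl on a saturated chain carbon, two bonds along the chain from a carbonyl carbon. Going by the values given here, no pair of measured compounds differs in this one place alone, so nothing measured shows what such a change does here. Compounds 1, 2 and 3 each carry a different chain on the carbonyl, but they also differ in their acids, so their numbers cannot be assigned to the chain.

The expected step of a number 2.9 percentage points lower from compound 1 to compound 4 (within the scatter) is therefore small, with no direction beyond the scatter. Compound 4 is expected to give about 54%, with a range from 32% to 74%.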

Compound 4, largest response reached (reported as percent of maximum), in percent of the reference or control that the assay uses: 18.4%
Compound 4: the middle estimate sits 35.6 percentage points above what was measured, and the stated range ends above it.
By their numbers in this assay, from the lowest: compounds 4 and 2 (each within the scatter of the next); then compounds 1 and 3 (each within the scatter of the next).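

In this assay, hydrogen in place of methyl on a saturated chain carbon, two bonds along the chain from a carbonyl carbon, gives a number 38.5 percentage points lower from compound 1 to compound 4 (beyond the scatter). Going by these compounds alone, this is the first pair to differ in this one place alone, and it shows that the maximal response depends on this position: the loss of a single carbon, propylcarbonyl to propanoyl, carries a step well beyond the scatter on the core of compound 1. Nothing available explains why the response drops with this change.

From the compounds shown here alone, whether a longer chain on the carbonyl would keep, raise or lower the response remains open. Also open, going by these compounds, is whether the same shortening would have a step of similar size on the acid parts of compound 2 and compound 3.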